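A Triazole Substituent Swap on a Weakly Active Chromene Core

This account rests on a few compounds, and the source may have more. Where it says the series, first, only, none or still open, it means among the compounds named here.

The account concerns two measured compounds and one that awaits measurement in a functional assay on DU-145 cells (Homo sapiens) for inhibition, read by MTT assay, with a stated time of 24 h; a higher number here means a weaker inhibitor, a lower number a stronger inhibitor. Compound 1, `CCCCCCCCn1cc(COC2(C(F)(F)F)Oc3ccccc3C=C2C(=O)OCC)nn1`, carries an octyl chain on the aromatic nitrogen of its five-membered ring. In this assay compound 1 gives only a limit of > 150000 nM, not a number. Compound 2, `CCOC(=O)C1=Cc2ccccc2OC1(OCc1cc(-c2ccc(OC)cc2)no1)C(F)(F)F`, differs in the heterocycle attached through the methylene linker, and it too reaches only a limit of > 150000 nM in this assay. Both compounds therefore sit at the limit of > 150000 nM in this assay, at which 2 of the 2 values shown sit, so nothing places compound 1 above or below any other compound here.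

Compound 3, `CCOC(=O)C1=Cc2ccccc2OC1(OCc1cn(-c2cccc(C(F)(F)F)c2)nn1)C(F)(F)F`, is made from compound 1 by the change (3-(trifluoromethyl)phenyl in place of octyl on an aromatic nitrogen), that is, 3-(trifluoromethyl)phenyl in place of octyl on an aromatic nitrogen. Going by the values given here, no measured pair shows what such a change does in this assay, and the shared core has so far given no number at all. The step expected from compound 1 to compound 3 is therefore a number no higher from compound 1 to compound 3 (the limit leaves the size open), meaning nothing beyond the scatter. Compound 3 is accordingly estimated at 150000 nM, with a range from 50000 nM to 300000 nM, and most likely the assay will again report only a limit.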

Compound 3, half-maximal inhibitory concentration: > 150000 nM
Compound 3 was reported as a limit; the forecaster's own chance of this, stated with the estimate: 80%; the middle value lies on the limit itself.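

In this assay compound 3 gives > 150000 nM, which is a limit and not a number. Compound 1 also gives only a limit, and no step can be read from compound 1 to compound 3. The compounds shown leave open how large the step from octyl to 3-(trifluoromethyl)phenyl is, and whether any group on the shared core gives a number in this assay.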